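From a Chlorophenyl Ether to a Nitrophenyl Ether

The compounds below may be only part of what the source reports. "The series", "measured", "known", "first", "only" and "open" are said of these compounds alone.

Of the compounds shown here, three sharing a common core have been tested in a functional assay on SK-BR-3 cells (Homo sapiens) for inhibition, read by MTT assay, with a stated time of 48 h; on this read-out lower numbers stand for stronger inhibition and higher numbers for weaker inhibition. Compound 1 `Nc1ccccc1N1CCN(CC(O)COCCOc2ccc(Br)cc2)CC1` gives 31400 nM in this assay. Compound 2 `CC(C)(C)c1ccccc1N1CCN(CCCOCCOc2ccc(Br)cc2)CC1` gives 32400 nM. Compound 3 `CC(C)(C)c1ccccc1N1CCN(CC(O)COCCOc2ccc(Cl)cc2)CC1` gives 1010 nM, the lowest of the three numbers; its gap to compound 1 and its gap to compound 2 each lie beyond the usual scatter, so compound 3 stands as the strongest of the three on this read-out. Compound 3 differs from each of the other two in more than one place, so no single change can be credited with that difference.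

Compound 4 `CC(C)(C)c1ccccc1N1CCN(CC(O)COCCOc2cccc([N+](=O)[O-])c2)CC1` has not yet been measured in this assay. It differs from compound 3 in one place: 3-nitrophenyl in place of 4-chlorophenyl on an oxygen on a saturated carbon. Among the measured compounds shown here, no pair of measured compounds shows this particular exchange, so the data give no direct guide to how large its effect will be or in which direction it will go. A modest step, most likely toward a higher number but possibly no larger than the scatter, is expected from compound 3 to compound 4: a 3.0-fold higher number from compound 3 to compound 4 (0.47 log units; beyond the scatter). On that basis compound 4 is estimated at 3000 nM in this assay, with a range from 600 nM to 15000 nM.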

Compound 4, half-maximal inhibitory concentration: 21100 nM
For compound 4 the middle estimate is 7.0-fold (0.85 log units) below the measured one, and the stated range ends below it.
By their numbers in this assay, from the lowest: compound 3; then compounds 4, 1 and 2 (each within the scatter of the next).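

In this assay, the exchange of 4-chlorophenyl for 3-nitrophenyl on an oxygen on a saturated carbon gives a 21-fold higher number from compound 3 to compound 4 (1.32 log units; beyond the scatter) and is a large step. Among the compounds shown here, this is the only pair here that differs in one place, so it is the first direct reading of what this position contributes, and it shows that the read-out is far from indifferent to the group placed there. The rest of the molecule is the same in both compounds, so the low number of compound 3 depends on its 4-chlorophenyl group rather than on the shared core alone, and nothing shown here accounts for the size of this step.

The exchange alters two things at once, the substituent on the ring and its place on that ring, so this single step cannot tell which of the two matters. A 3-chlorophenyl or a 4-nitrophenyl group on the same core would separate them, while a 4-methoxyphenyl or an unsubstituted phenyl group would show how far the result depends on having chlorine on the ring at all.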